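Vinyl in Place of Chloro on the Exocyclic Double Bond

The compounds below may be only part of what the source reports. "The series", "measured", "known", "first", "only" and "open" are said of these compounds alone.

Compound 1, `CC1=C/C(=C\c2ccccc2)C(=O)C(C)(O)C12CC2`: 2500 nM
Compound 2, `CC1=C/C(=C\Cl)C(=O)C(C)(O)C12CC2`: 30 nM

Both compounds were tested in a functional assay on SW480 cells (Homo sapiens) for antiproliferative activity; on this read-out higher numbers stand for weaker inhibition and lower numbers for stronger inhibition. Compound 2 holds the lowest of the two numbers; its nearest neighbour is compound 1, and the step of an 83-fold lower number from compound 1 to compound 2 (1.92 log units; beyond the scatter) separates them. Compound 3, `C=C/C=C1\C=C(C)C2(CC2)C(C)(O)C1=O`, has not yet been measured. Its change from compound 2 is this: vinyl in place of chloro on a double-bonded chain carbon bound to a double-bonded ring carbon.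

Going by the values given here, only one measured step touches this position, an 83-fold lower number from compound 1 to compound 2 (1.92 log units; beyond the scatter), and it is large. Among the compounds with values here, compound 3 carries neither the chloro of compound 2 nor the phenyl of compound 1 at that carbon, and no measured compound shows what a vinyl group does there. Within the data shown here, the single step points to a position where the group matters a great deal, so a number above that of compound 2, yet well below that of compound 1, is expected. The expected step from compound 2 to compound 3 is a 3.3-fold higher number from compound 2 to compound 3 (0.52 log units; beyond the scatter). Compound 3 is therefore estimated to give 100 nM in this assay, within a range from 20 nM to 500 nM.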

Compound 3, half-maximal inhibitory concentration: 180 nM
The estimate for compound 3 lay 1.8-fold (0.26 log units) below the measured number, within the range that was stated.
By their numbers in this assay, from the lowest: compound 2; then compound 3; then compound 1.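

With compound 3, this position on a double-bonded chain carbon bound to a double-bonded ring carbon carries three groups, and in this assay they now form a graded series rather than a single contrast: chloro gives the lowest number, vinyl the middle one and phenyl the highest. Replacing phenyl with vinyl already gives a 14-fold lower number from compound 1 to compound 3 (1.14 log units; beyond the scatter), while replacing chloro with vinyl gives a 6.0-fold higher number from compound 2 to compound 3 (0.78 log units; beyond the scatter), so the large difference seen earlier is not an all-or-nothing split between chloro and phenyl, and a carbon group at this position can still give a number far lower than the one phenyl gives. Nothing among the available data explains why the three groups fall in this order.

The compounds shown leave open whether another halogen, such as fluoro or bromo, would match chloro here, and whether a methyl group or a nitrile would fall closer to chloro or to vinyl. They also leave open how a longer chain in place of vinyl, or a phenyl bearing a methoxy group, would compare on this read-out.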